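This account rests on a few compounds, and the source may have more. Where it says the series, first, only, none or still open, it means among the compounds named here.

Measured compounds and their values:

- Compound 1, `Cc1nc(N)c2c(-c3cccs3)cn([C@@H]3O[C@H](CO)[C@@H](O)[C@H]3O)c2n1`, > 20000 nM
- Compound 2, `Cc1nc(N)c2c(-c3ccco3)cn([C@@H]3O[C@H](CO)[C@@H](O)[C@H]3O)c2n1`, > 20000 nM
- Compound 3, `Nc1nc2c(c(-c3ccco3)cn2[C@@H]2O[C@H](CO)[C@@H](O)[C@H]2O)c(=O)[nH]1`, > 20000 nM

The three compounds were tested in a functional assay on CEM-DNR-bulk cells (Homo sapiens), read by MTT assay, with a stated time of 72 h; on this read-out lower numbers stand for stronger inhibition and higher numbers for weaker inhibition. The value given for compound 1 is a limit of the assay, not a number. For compound 2 the value is likewise a limit. For compound 3 the value is again a limit. Compound 1 and compound 2 share a core and differ by thiophen-2-yl in place of furan-2-yl on an aromatic carbon; the step that the two limits leave unreadable from compound 2 to compound 1 cannot be read, since both values are limits. The core of compound 3 differs from that of compound 2, and the difference between the two cores is not broken down here.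

Compound 4, `Nc1nc2c(c(-c3cccs3)cn2[C@@H]2O[C@H](CO)[C@@H](O)[C@H]2O)c(=O)[nH]1`, has not yet been measured in this assay. It differs from compound 3 by thiophen-2-yl in place of furan-2-yl on an aromatic carbon, the same kind of change that leads from compound 2 to compound 1. The only support for an expectation is the limit of > 20000 nM in this assay, at which 3 of the 3 values shown sit. Given that every measured compound, including compound 3 with > 20000 nM, sits at this limit, compound 4 is expected to sit there as well. The step that the limit leaves unreadable from compound 3 to compound 4 is therefore estimated to be about flat. Compound 4 is estimated at 30000 nM in this assay, within a range from 10000 nM to 100000 nM, most likely reported only as a limit.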

Compound 4, half-maximal inhibitory concentration: > 20000 nM
Compound 4: a limit, no number; the forecaster's own chance of this, stated with the estimate: 85%; the middle value does not contradict the limit.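

No step can be read from compound 3 to compound 4, as the values of both in this assay are limits and not numbers. The compounds shown leave open how strongly any of them inhibits, and whether thiophen-2-yl in place of furan-2-yl changes the read-out on either core, with only this to go on: the limit of > 20000 nM in this assay, at which 4 of the 4 values shown sit.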